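This account rests on a few compounds, and the source may have more. Where it says the series, first, only, none or still open, it means among the compounds named here.

Compound 3 `Cc1c(C(=O)N/N=C\c2cccc(F)c2)oc2cccc(O)c12` is one of three measured members of a shared core, alongside compound 1 `Cc1c(C(=O)N/N=C\c2ccccc2F)oc2cccc(O)c12` and compound 2 `Cc1c(C(=O)N/N=C\c2ccccc2O)oc2cccc(O)c12`. In a functional assay on PC-3 cells (Homo sapiens) for inhibition (on this read-out higher numbers stand for weaker inhibition and lower numbers for stronger inhibition), compound 3 returns only a limit, >= 40000 nM. Compound 1 likewise reaches only a limit, >= 40000 nM. For the measured compounds named here, compound 2 is the single member with a true number, giving 8350 nM in this assay. Two of the three values therefore sit at the same point, (the limit of >= 40000 nM in this assay, at which 2 of the 3 values shown sit), so compound 3 stands at the weak end of what this assay can read. Compound 4 `Cc1c(C(=O)N/N=C\c2c(O)cccc2F)oc2cccc(O)c12` is the unmeasured partner, and the change is 2-fluoro-6-hydroxyphenyl in place of 3-fluorophenyl on a carbon with a double bond to nitrogen. Going by the values given here, two measured steps bear on it. The step of an at least 4.7-fold lower number from compound 1 to compound 2 (0.68 log units; beyond the scatter) shows a hydroxy in place of fluoro bringing the number well down, and the step of an at least 4.7-fold higher number from compound 2 to compound 3 (0.68 log units; beyond the scatter) shows the reverse when the hydroxyphenyl is given up for a fluorophenyl; the step that the two limits leave unreadable from compound 1 to compound 3 adds nothing readable. Compound 4 keeps the fluorine and gains the hydroxy, so a fall in the number is expected, though compound 1 carries 2-fluorophenyl while compound 3 carries 3-fluorophenyl. Compound 4 is expected to show an at least 4.0-fold lower number from compound 3 to compound 4 (0.60 log units; beyond the scatter). For compound 4 the estimate is 10000 nM, with a range from 3000 nM to 40000 nM.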

Compound 4, half-maximal inhibitory concentration: 8050 nM
For compound 4 the middle estimate is 1.2-fold (0.09 log units) above the measured one; the measured number falls inside the stated range.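

In this assay, the 2-fluoro-6-hydroxyphenyl group on the carbon with a double bond to nitrogen brings a measurable number where the fluorophenyl groups alone gave none, with an at least 4.9-fold lower number from compound 3 to compound 4 (0.69 log units; beyond the scatter) and, for hydroxy in place of hydrogen, an at least 4.9-fold lower number from compound 1 to compound 4 (0.69 log units; beyond the scatter). Fluoro in place of hydrogen on the hydroxyphenyl ring leaves the reading unchanged, with a 1.0-fold lower number from compound 2 to compound 4 (0.02 log units; within the scatter), so among these four compounds the two that carry the ring hydroxy give numbers, and the added fluorine does not take that away. Compound 1 and compound 3 are read only as a limit, so the true size of the first two steps stays unknown: the limit of >= 40000 nM in this assay, at which 2 of the 4 values shown sit.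

The compounds shown leave open whether a methoxy or an amino group in place of the ring hydroxy would keep the number at this level. They also leave open how a plain unsubstituted phenyl would read, and whether a hydroxy placed elsewhere on this ring would serve as well.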